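This account rests on a few compounds, and the source may have more. Where it says the series, first, only, none or still open, it means among the compounds named here.

In a functional assay on DU-145 cells (Homo sapiens) for cytotoxicity (a higher number here means a weaker inhibitor of growth, a lower number a stronger inhibitor of growth), compound 1 `COc1ccc(C2=C(c3ccc(SC)cc3)CC3CCCN3C2=O)cc1` gives 900 nM and compound 3 `CSc1ccc(C2=C(c3ccc(C)cc3)C(=O)N3CCCC3C2)cc1` gives 600 nM, so compound 3 stands level with compound 1, within the scatter. Compound 2 `CSc1ccc(C2=C(c3ccc(O)cc3)C(=O)N3CCCC3C2)cc1` gives > 100000 nM, which is a limit of the assay. Compound 4 `CSc1ccc(C2=C(c3ccc(SC)cc3)C(=O)N3CCCC3C2)cc1` differs from compound 3 by methylsulfanyl in place of methyl on an aromatic carbon, para to a large group. Within the data shown here, two measured steps bear on this place: a 1.5-fold lower number from compound 1 to compound 3 (0.18 log units; within the scatter) is small, while an at least 160-fold lower number from compound 2 to compound 3 (2.22 log units; beyond the scatter) is large and involves the hydroxy compound. Compound 4 carries no hydroxy there, so the closer guide is the small step. The expected change is none beyond the scatter, a 1.2-fold lower number from compound 3 to compound 4 (0.08 log units; within the scatter). For compound 4 the estimated value is 500 nM, with an expected range of 150 nM to 1800 nM.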

Compound 4, concentration for 50% growth inhibition: 8000 nM
Compound 4: middle estimate off by 16-fold (1.20 log units), on the low side; measured number above the stated range.
By their numbers in this assay, from the lowest: compounds 3 and 1 (each within the scatter of the next); then compound 4. At a limit, above all of these: compound 2.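

In this assay, this aromatic carbon, para to a large group, tolerates methoxy and methyl alike but not methylsulfanyl: the change from methyl gives a 13-fold higher number from compound 3 to compound 4 (1.12 log units; beyond the scatter), and the change from methoxy gives an 8.9-fold higher number from compound 1 to compound 4 (0.95 log units; beyond the scatter). The small earlier step therefore does not extend to every group without a hydroxy here. The hydroxy compound stands at a limit, so an at least 12-fold lower number from compound 2 to compound 4 (1.09 log units; beyond the scatter) is a bound and not a size: the limit of > 100000 nM in this assay, at which 1 of the 4 values shown sits.

From the compounds shown here alone, it remains open whether the higher number follows the sulfur itself or the group as a whole. Going by these compounds, how an amine, a fluorine or a longer chain would read at this place also remains open.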